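A few compounds are considered here, and "the series" means these few. Any claim that something is new, unique, unknown or untested is made for them only; others in the source may bear on it.

Measured in a functional assay on 786-0 cells (Homo sapiens) for inhibition, read by sulforhodamine B assay, with a stated time of 48 h; a lower number here means a stronger inhibitor of growth, a higher number a weaker inhibitor of growth:
compound 1 `CC1=CC[C@H](C(C)(C)N=C=S)CC1` gives > 100000 nM, a limit of this assay and not a number.
compound 2 `COc1ccc(/C=N/NC(=S)NC(C)(C)[C@H]2CC=C(C)CC2)cc1` gives 29600 nM.
compound 3 `CC1=CC[C@H](C(C)(C)NC(=S)N/N=C/c2cccc([N+](=O)[O-])c2)CC1` gives > 100000 nM, again a limit.

Within the data shown here, compound 2 thus carries the only numeric value of the three in this assay; compound 1 and compound 3 both rest at the limit of > 100000 nM in this assay, at which 2 of the 3 values shown sit. Compound 4 `CC1=CC[C@H](C(C)(C)NC(=S)N/N=C/c2ccco2)CC1` has not been measured. It differs from compound 2 by furan-2-yl in place of 4-methoxyphenyl on a carbon with a double bond to nitrogen. Among the measured compounds shown here, no measured pair differs in one place only, so no step size comes from the set itself. Since compound 1 and compound 3 sit at the limit of > 100000 nM in this assay, at which 2 of the 3 values shown sit, a modest loss is expected along a 1.5-fold higher number from compound 2 to compound 4 (0.18 log units; within the scatter). Compound 4 is estimated at 45000 nM, with a range from 15000 nM to 110000 nM and a real chance of only a limit.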

Compound 4, concentration for total growth inhibition: 9800 nM
Beside the measured number, compound 4's estimate is 4.6-fold (0.66 log units) above it; the measured number lies below the stated range.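

In this assay, furan-2-yl in place of 4-methoxyphenyl on a carbon with a double bond to nitrogen gives a 3.0-fold lower number from compound 2 to compound 4 (0.48 log units; beyond the scatter). Among these compounds, this is the only readable step, and it shows that this position tolerates exchange of the six-membered aromatic ring for a five-membered one with a lower number, not a loss to a limit. The other values give no further step here: the limit of > 100000 nM in this assay, at which 2 of the 4 values shown sit.

Going by these compounds, whether a thiophen-2-yl or pyridin-3-yl ring at this position continues the direction stays open. So does whether an amine on the furan-2-yl ring changes the number.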